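The source may report more compounds than this note shows. Statements on the series, on what has been measured and on what is new or still open speak of the compounds shown alone.

Measured compounds:
compound 1 `COc1c(O)cc(O)c2c(=O)cc(-c3ccc(N4CCCNCC4)cc3)oc12` with 31600 nM
compound 2 `COc1c(O)cc(O)c2c(=O)cc(-c3ccc(N4CCN(C=O)CC4)cc3)oc12` with 2200 nM

In an assay on cells for inhibition of ubiquitin carboxyl-terminal hydrolase 8 (Homo sapiens), read by fluorescence, with a stated time of 30 min (on this read-out higher numbers stand for weaker inhibition and lower numbers for stronger inhibition), compound 2 holds the lower of the two numbers in hand; its nearest neighbour is compound 1, and the step of a 14-fold lower number from compound 1 to compound 2 (1.16 log units; beyond the scatter) separates them. Compound 3 `COc1c(O)cc(O)c2c(=O)cc(-c3ccc(N4CCCC4)cc3)oc12` has not yet been measured. It differs from compound 2 in one place: pyrrolidin-1-yl in place of 4-formylpiperazin-1-yl on an aromatic carbon.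

Among the measured compounds shown here, only one measured step speaks to this change. The step from compound 1 to compound 2 shows that exchanging one saturated nitrogen ring for another on the same aromatic carbon can move this assay by a large amount. For the measured compounds named here, that exchange, however, swapped 1,4-diazepan-1-yl for 4-formylpiperazin-1-yl, whereas the present one swaps 4-formylpiperazin-1-yl for pyrrolidin-1-yl; no measured pair isolates the loss of the formyl group or the shrinking of the ring. The expectation for compound 3 is therefore uncertain and is placed a modest step upward, a 2.3-fold higher number from compound 2 to compound 3 (0.36 log units; beyond the scatter), with a wide range. Compound 3 is estimated to give 5000 nM in this assay, between 1500 nM and 20000 nM.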

Compound 3, half-maximal inhibitory concentration: 16200 nM
The estimate for compound 3 lay 3.2-fold (0.51 log units) below the measured number; the range from low to high includes it.
By their numbers in this assay, from the lowest: compound 2; then compounds 3 and 1 (each within the scatter of the next).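

In this assay, the change to pyrrolidin-1-yl gives a 7.4-fold higher number from compound 2 to compound 3 (0.87 log units; beyond the scatter) and so shows that a second exchange of saturated nitrogen rings on this aromatic carbon also moves the read-out beyond the scatter, this time towards weaker inhibition. The step of a 2.0-fold lower number from compound 1 to compound 3 (0.29 log units; within the scatter) lies within the scatter, so pyrrolidin-1-yl and 1,4-diazepan-1-yl cannot be told apart here, although one ring is five-membered with one hetero atom and the other carries a second ring nitrogen. Among the three groups at this position, only 4-formylpiperazin-1-yl stands apart, with compound 2 at 2200 nM and its steps to both other compounds beyond the scatter. Nothing given here accounts for these differences in the read-out.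

The compounds shown leave open whether the lower number of compound 2 belongs to the formyl group or to the piperazine ring that carries it, since the two always occur together in this series. On these data alone, a plain piperazin-1-yl, a 4-acetylpiperazin-1-yl or a morpholin-4-yl group at the same place would each bear on that question, and the effect of any of them on the read-out remains unknown.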